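Indolyl for quinolinyl on the enaminone amine nitrogen

The source may report more compounds than this note shows. Statements on the series, on what has been measured and on what is new or still open speak of the compounds shown alone.

Measured so far:
- compound 1 `O=C(/C=C\Nc1cnc2ccccc2c1)c1nc(-c2ccc(C(F)(F)F)cc2)n2ccccc12`: > 30000 nM
- compound 2 `O=C(/C=C\Nc1cnc2ccccc2c1)c1nc(-c2ccccc2)n2ccccc12`: 3780 nM

Compound 1 was tested in a functional assay on B16-F10 cells (Mus musculus) for cytotoxicity, read by MTT assay, with a stated time of 48 h (a lower number here means a stronger inhibitor, a higher number a weaker inhibitor), and its result there is only a limit of the assay, > 30000 nM, not a measured number (the limit of > 30000 nM in this assay, at which 1 of the 2 values shown sits). Compound 2 differs from compound 1 by hydrogen in place of trifluoromethyl on an aromatic carbon; in this assay compound 2 gives 3780 nM, so the step is an at least 7.9-fold lower number from compound 1 to compound 2 (0.89 log units; beyond the scatter), and it runs toward a lower number.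

Compound 3 `O=C(/C=C\Nc1ccc2[nH]ccc2c1)c1nc(-c2ccc(C(F)(F)F)cc2)n2ccccc12` keeps the trifluoromethyl of compound 1 and changes a different part of the molecule: 1H-indol-5-yl in place of quinolin-3-yl on an amine nitrogen. Going by the values given here, no measured step touches the group on the amine nitrogen, so the single known step, which concerns the aromatic carbon, offers no direct guide to this change. With compound 1 sitting at the limit, the size of any real step from it cannot be read from the numbers shown.

The estimate therefore stays near where compound 1 stands: compound 3 is expected to give about 30000 nM in this assay, within 6000 nM to 100000 nM, with the step of a number no higher from compound 1 to compound 3 (the limit leaves the size open) expected to be no larger than the scatter, and compound 3 may well be expected to sit at the limit of the assay again.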

Compound 3, half-maximal inhibitory concentration: 18200 nM
Estimate against measurement, compound 3: 1.6-fold (0.22 log units) above; the measured number falls inside the stated range.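

In this assay compound 3 gives 18200 nM, the only measured number shown for a compound carrying the trifluoromethyl group, so with that group in place the reading on the amine nitrogen's substituent can fall inside the range of the assay. Putting 1H-indol-5-yl in place of quinolin-3-yl gives an at least 1.6-fold lower number from compound 1 to compound 3 (0.21 log units; that floor lies within the scatter), the first step shown at this position, and the printed floor alone does not establish a real difference. The true size of the step cannot be read, because it is bounded on one side only: the limit of > 30000 nM in this assay, at which 1 of the 3 values shown sits.

The compounds shown leave open whether the step seen on removing the trifluoromethyl group, an at least 7.9-fold lower number from compound 1 to compound 2 (0.89 log units; beyond the scatter), would also appear with 1H-indol-5-yl on the amine nitrogen, which would need the compound carrying that group and an unsubstituted phenyl. They also leave open whether the hydrogen on the indole nitrogen matters, a question that a methyl group on that nitrogen could address, and how a simple phenyl or a pyridine ring on the amine nitrogen would read in this assay.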